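The source may hold more compounds than are shown below. What is called first, only, known or untested is meant among the compounds shown, and "the series" means these compounds.

In a functional assay on KG-1 cells (Homo sapiens) for cytotoxicity, read by luminescence and CellTiter-Glo, with a stated time of 3 days (on this read-out lower numbers stand for stronger inhibition and higher numbers for weaker inhibition), compound 1 (`COc1ccc(O)c(C(=O)Nc2ccc(C#N)cc2)c1`) reads > 10000 nM, which is a limit of the assay and not a number. Among the compounds with values here, compound 2 (`N#Cc1ccc(NC(=O)c2cc(-c3ccncc3)ccc2O)cc1`) gives 7990 nM, the only true number so far in this assay, so its standing cannot yet be ranked against another measured value.

The next compound is compound 3 (`N#Cc1ccc(NC(=O)c2cc(-c3ccccc3)ccc2O)cc1`), with phenyl in place of pyridin-4-yl on an aromatic carbon, para to a hydroxy group: phenyl in place of pyridin-4-yl on an aromatic carbon. Within the data shown here, only one measured step involves this place on the shared core, namely an at least 1.2-fold lower number from compound 1 to compound 2 (0.09 log units; that floor lies within the scatter). That step replaced methoxy with pyridin-4-yl, and its floor does not clear the scatter. It therefore gives no measured size for exchanging one six-membered aromatic ring for another, and it offers no firm direction. On this thin basis, no shift beyond the scatter is expected in this assay, and the expected step is a 1.3-fold lower number from compound 2 to compound 3 (0.12 log units; within the scatter). The estimate for compound 3 is 6000 nM, with an expected range of 2000 nM to 13000 nM.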

Compound 3, half-maximal inhibitory concentration: 1300 nM
Compound 3: middle estimate off by 4.6-fold (0.66 log units), on the high side; measured number below the stated range.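

Within the data shown here, with phenyl in place of pyridin-4-yl on an aromatic carbon, para to a hydroxy group, this assay gives a 6.1-fold lower number from compound 2 to compound 3 (0.79 log units; beyond the scatter), the first step at this place that clears the scatter. Both groups are six-membered aromatic rings with the same count of heavy atoms, and the exchange removes the one ring nitrogen with its hydrogen-bond acceptor, so at this place the number depends on more than the ring size of the group. Phenyl in place of methoxy gives an at least 7.6-fold lower number from compound 1 to compound 3 (0.88 log units; beyond the scatter), a floor and not a full size, since compound 1 sits at a limit of the assay and not at a number: the limit of > 10000 nM in this assay, at which 1 of the 3 values shown sits.

The compounds shown leave open whether the position of the ring nitrogen matters, as pyridin-3-yl would test, and whether phenyl itself can be improved with an added amine, carboxylic acid or methoxy on that ring. They also leave open how far the nitrile and the hydroxy group on the shared core contribute, since both stay unchanged across compound 1, compound 2 and compound 3.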